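Replacing chloro with ethoxy on the shared core

The source may hold more compounds than are shown below. What is called first, only, known or untested is meant among the compounds shown, and "the series" means these compounds.

In a functional assay on K562 cells (Homo sapiens) for antiproliferative activity, read by MTT assay, with a stated time of 72 h (on this read-out lower numbers stand for stronger inhibition and higher numbers for weaker inhibition), compound 1 `COc1cc(C(=O)c2sc3ccccc3c2Nc2ccccc2)cc(OC)c1OC` gives 2300 nM while compound 2 `COc1cc(C(=O)c2sc3ccccc3c2Nc2ccc(Cl)cc2)cc(OC)c1OC` gives 1100 nM as the lower of the two numbers. Compound 3 `CCOc1ccc(Nc2c(C(=O)c3cc(OC)c(OC)c(OC)c3)sc3ccccc23)cc1` carries ethoxy in place of chloro on an aromatic carbon and awaits measurement. Among the measured compounds shown here, the only measured step that bears on this is a 2.1-fold lower number from compound 1 to compound 2 (0.32 log units; beyond the scatter) when chloro replaces hydrogen at that place, a modest change that says nothing directly about ethoxy. A similarly small move toward a higher number is therefore expected in this assay as chloro leaves, estimated as a 1.4-fold higher number from compound 2 to compound 3 (0.13 log units; within the scatter) here. Compound 3 is expected at 1500 nM (range 500 nM to 4500 nM).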

Compound 3, half-maximal inhibitory concentration: 200 nM
Compound 3: middle estimate off by 7.5-fold (0.88 log units), on the high side; measured number outside the range, below it.
By their numbers in this assay, from the lowest: compound 3; then compound 2; then compound 1.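

In this assay this place, para to a large group, carries ethoxy with a clear gain: there is a 5.5-fold lower number from compound 2 to compound 3 (0.74 log units; beyond the scatter) and, against the unsubstituted ring, a 12-fold lower number from compound 1 to compound 3 (1.06 log units; beyond the scatter) as a large step where chloro gave only a modest one. The size of the effect thus differs sharply between the two groups at this one place. Nothing available accounts for the difference.

Going by these compounds, whether methoxy, a longer chain such as butoxy, or an amine would follow ethoxy here remains open. So does whether ethoxy would give the same result elsewhere on this ring.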